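A Fluoro Swap on an Unmeasured Amine

A few compounds are considered here, and "the series" means these few. Any claim that something is new, unique, unknown or untested is made for them only; others in the source may bear on it.

- compound 1 `COc1cc(O)ccc1/C=C/C(=O)c1ccc(NC(C)=O)cc1`: 17400 nM
- compound 2 `COc1cc(O)ccc1/C=C/C(=O)c1ccc(N)cc1`: "not determined" (no result reported)

In a functional assay on SNU-638 cells (Homo sapiens) for cytotoxicity, read by MTT assay (a higher number here means a weaker inhibitor, a lower number a stronger inhibitor), compound 1 gives 17400 nM. Compound 2 has no number to stand on, its entry reading "not determined" (no result reported). The change considered here is fluoro in place of amino on an aromatic carbon. It leads to compound 3 `COc1cc(O)ccc1/C=C/C(=O)c1ccc(F)cc1`, which has yet to be measured. Among the measured compounds shown here, no step from compound 2 can be sized, so the only guide is compound 1 at 17400 nM, and a value within the scatter of that one is expected. Compound 3 is estimated at 14000 nM, with an expected range of 5000 nM to 40000 nM.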

Compound 3, half-maximal inhibitory concentration: 6300 nM
The estimate for compound 3 lay 2.2-fold (0.35 log units) above the measured number, within the range that was stated.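

In this assay the place para to a large group now has two groups that can be compared: fluoro in place of acetamido gives a 2.8-fold lower number from compound 1 to compound 3 (0.44 log units; beyond the scatter) and this modest step lies beyond the usual scatter. The acetamido group is therefore not required for the cytotoxicity seen with the shared core. Nothing available bears on the cause of this step. Steps involving compound 2 cannot be read, so the amino group remains unplaced in this comparison. Going by these compounds, how a chlorine atom, a nitrile or a trifluoromethyl group would compare with fluoro at this place stays open.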